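Fluorine Position and Tolerated Concentration in Huh-7 Cells

The source may report more compounds than this note shows. Statements on the series, on what has been measured and on what is new or still open speak of the compounds shown alone.

Compound 2 `Oc1c(O)c(O)c2c(=S)cc(-c3ccccc3)oc2c1-c1cccc(F)c1` was examined in a toxicity assay on Huh-7 cells (Homo sapiens) for cytotoxicity, read by CCK-8 assay, with a stated time of 24 h; a lower number here means that less compound is tolerated, a higher number that more compound is tolerated. For compound 2 the result is a limit of the assay, > 100000 nM, and not a number. Compound 1 `O=c1cc(-c2ccccc2)oc2c(-c3ccc(F)cc3)c(O)c(O)c(O)c12` likewise gives only a limit, > 100000 nM. Compound 3 `O=c1cc(-c2ccc(Nc3ccc(Br)cc3)cc2)oc2cc(O)c(O)c(O)c12` also reaches only a limit, > 100000 nM. Compound 2 thus stands at the limit of > 100000 nM in this assay, at which 3 of the 3 values shown sit, and no ordering among the three is possible. Compound 4 `Oc1c(O)c(O)c2c(=S)cc(-c3ccccc3)oc2c1-c1ccc(F)cc1` has not yet been measured in this assay. It differs from compound 2 by 4-fluorophenyl in place of 3-fluorophenyl on an aromatic carbon. Among the compounds with values here, no step between measured compounds is available to size this change; with every value so far at the limit, no step beyond the scatter is expected in either direction. Compound 4 is therefore expected to give 150000 nM, between 60000 nM and 400000 nM, which as an expected step means a step that the limit leaves unreadable from compound 2 to compound 4.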

Compound 4, half-maximal cytotoxic concentration: > 100000 nM
Compound 4 was reported as a limit (the forecaster's own chance of this, stated with the estimate: 90%); the middle value does not contradict the limit.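

Compound 2 and compound 4 both give only a limit in this assay, so no step can be read between them. The compounds shown leave open how 4-fluorophenyl and 3-fluorophenyl compare on the shared core.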